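From 4-fluorophenyl to phenyl in a small thiosemicarbazone set

The source may report more compounds than this note shows. Statements on the series, on what has been measured and on what is new or still open speak of the compounds shown alone.

Measured in a functional assay on HeLa cells (Homo sapiens) for antiproliferative activity, read by sulforhodamine B assay, with a stated time of 72 h (a lower number here means a stronger inhibitor, a higher number a weaker inhibitor), so far:
- compound 1 `FC(F)(F)c1ccccc1NC(=S)N/N=C/c1ccc2ccccc2n1` gives 18800 nM
- compound 2 `N#Cc1ccc(NC(=S)N/N=C/c2ccc3ccccc3n2)cc1` gives 20000 nM
- compound 3 `Fc1ccc(NC(=S)N/N=C/c2ccc3ccccc3n2)cc1` gives 33200 nM

Compound 3 stands within the scatter of both compound 1 and compound 2, so the three values give no order among these compounds. The next compound, compound 4 `S=C(N/N=C/c1ccc2ccccc2n1)Nc1ccccc1`, differs from compound 3 by hydrogen in place of fluoro on an aromatic carbon in one place, hydrogen in place of fluoro on an aromatic carbon, which turns 4-fluorophenyl to phenyl. Going by the values given here, one measured step bears on this place, namely a 1.7-fold higher number from compound 2 to compound 3 (0.22 log units; within the scatter) for fluoro in place of cyano. Among the compounds with values here, no measured compound shows the effect of leaving that place unsubstituted, so the estimate rests on this single small step. The expected outcome is a 1.2-fold lower number from compound 3 to compound 4 (0.07 log units; within the scatter) in this assay, which means no expected change beyond the scatter and no firm direction. Compound 4 is estimated at 28000 nM with 13000 nM to 55000 nM as its expected range.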

Compound 4, half-maximal inhibitory concentration: 27400 nM
Compound 4: middle estimate off by 1.0-fold (0.01 log units), on the high side; the range from low to high includes it.
By their numbers in this assay, from the lowest: compounds 1, 2, 4 and 3 (each within the scatter of the next).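

In this assay, the position para to a large group now has an unsubstituted reference, and hydrogen in place of fluoro stays within the scatter (a 1.2-fold lower number from compound 3 to compound 4 (0.08 log units; within the scatter)). The same holds when compound 4 is set against the nitrile and trifluoromethyl compounds (a 1.4-fold higher number from compound 2 to compound 4 (0.14 log units; within the scatter); a 1.5-fold higher number from compound 1 to compound 4 (0.16 log units; within the scatter)), so none of these three groups is separated from hydrogen on an aromatic carbon in this set. No evidence is available to account for how close these values lie.

As far as these compounds go, whether an amine, a carboxylic acid or a methoxy group on this carbon would give a number beyond the scatter remains open. The compounds shown also leave open how changes to the shared core would read in this assay, since all four keep it.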